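This account rests on a few compounds, and the source may have more. Where it says the series, first, only, none or still open, it means among the compounds named here.

In an ADME assay on HUVEC cells (Homo sapiens) for antiproliferative activity, read by MTT assay, with a stated time of 48 h (a higher number here means a weaker inhibitor, a lower number a stronger inhibitor), compound 1 `N#CC1=C(N)Oc2c(c3nc4ccccc4nc3c3ccccc23)C12C(=O)N(Cc1cnnn1-c1ccc(F)cc1)c1ccccc12` gives > 50000 nM, which is a limit of the assay and not a number. Compound 2 `CC(=O)Nc1ccc(-n2nncc2CN2C(=O)C3(C(C#N)=C(N)Oc4c3c3nc5ccccc5nc3c3ccccc43)c3ccccc32)cc1` gives > 50000 nM in this assay, again a limit rather than a number. Among the compounds with values here, the one step between two measured compounds that differ in one place, acetamido in place of fluoro on an aromatic carbon, runs a step that the two limits leave unreadable from compound 1 to compound 2, so its size cannot be read. Compound 3 `Cc1ccccc1-n1nncc1CN1C(=O)C2(C(C#N)=C(N)Oc3c(N)cc4nc5ccccc5nc4c32)c2ccccc21` gives > 50000 nM in this assay, a limit and not a number. Within the data shown here, all three measured values therefore sit at the same point, (the limit of > 50000 nM in this assay, at which 3 of the 3 values shown sit), and no compound can be placed above or below another.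

Compound 4 `CCOc1ccccc1-n1nncc1CN1C(=O)C2(C(C#N)=C(N)Oc3c(N)cc4nc5ccccc5nc4c32)c2ccccc21` has not been measured in this assay. It differs from compound 3 as follows: ethoxy in place of methyl on an aromatic carbon. Among the measured compounds shown here, no measured step touches this change, and the single measured step cannot be sized, so there is nothing that would set a direction or a size for compound 4. Given that compound 3 gives only > 50000 nM, the expectation for compound 4 is that it too stays at the limit, and the step is estimated as a step that the limit leaves unreadable from compound 3 to compound 4. Compound 4 is thus expected to give about 60000 nM, within a range from 20000 nM to 200000 nM.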

Compound 4, half-maximal inhibitory concentration: > 50000 nM
Compound 4: only a limit was reported (the forecaster's own chance of this, stated with the estimate: 85%); the middle value lies beyond the limit too.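

In this assay compound 4 gives > 50000 nM, a limit and not a number. No step can be read between compound 3 and compound 4, and all the compounds shown share one point: the limit of > 50000 nM in this assay, at which 4 of the 4 values shown sit.

The compounds shown leave open what size or direction the change from 2-methylphenyl to 2-ethoxyphenyl has, and whether any of these compounds has a measurable value in this assay.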